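Naphthalen-1-yl on the ring nitrogen: compound 4 foreseen

The source may report more compounds than this note shows. Statements on the series, on what has been measured and on what is new or still open speak of the compounds shown alone.

Measured so far:
- compound 1, `COc1ccc(N2CCN(Cc3csc(N)c3C(=O)c3ccc(Cl)cc3)CC2)cc1`: 0%
- compound 2, `Nc1scc(CN2CCN(c3ccc([N+](=O)[O-])cc3)CC2)c1C(=O)c1ccc(Cl)cc1`: 1%
- compound 3, `Nc1scc(CN2CCN(c3ccc(Cl)c(C(F)(F)F)c3)CC2)c1C(=O)c1ccc(Cl)cc1`: 0%

All three share a core and differ only in the aromatic group on the ring nitrogen of the six-membered ring with two nitrogens. In an assay on CHO cells for displacement of a labelled ligand from adenosine receptor A1 (Homo sapiens), read by scintillation counting, with a stated time of 120 min, tested at 10 uM (a higher number here means more inhibition at the concentration tested (going by the name of the read-out), a lower number less inhibition), compound 1 gives 0%, and in this assay compound 2 gives 1%. Compound 3 gives 0% in this assay, level with compound 1; from compound 2 the step is a number 1 percentage points lower from compound 2 to compound 3 (within the scatter), and from compound 1 it is no change at the digits printed from compound 1 to compound 3 (within the scatter). Compound 3 therefore sits with the others at the bottom of the scale, and none of the values is separated from another beyond the scatter.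

Compound 4 is `Nc1scc(CN2CCN(c3cccc4ccccc34)CC2)c1C(=O)c1ccc(Cl)cc1`. It differs from compound 3 in one place: naphthalen-1-yl in place of 4-chloro-3-(trifluoromethyl)phenyl on an amine nitrogen in a ring. The steps already seen, a number 1 percentage points higher from compound 1 to compound 2 (within the scatter) and no change at the digits printed from compound 1 to compound 3 (within the scatter), both change the same aromatic group and both stay within the scatter. Exchanging one aromatic group for another on this nitrogen has so far moved nothing, so the expected step is a number 1 percentage points higher from compound 3 to compound 4 (within the scatter), no change beyond the scatter. Compound 4 is therefore estimated at 1% in this assay, with a range from -8% to 12%.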

Compound 4, a percentage reported as inhibition, at one concentration (the size of the read-out at that concentration, not a potency): 1%
Compound 4: the middle estimate sits on the measured number at the digits printed; the range from low to high includes it.
By their numbers in this assay, from the lowest: compounds 1, 3, 2 and 4 (each within the scatter of the next).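

Naphthalen-1-yl brings two six-membered aromatic rings of carbon only to the amine nitrogen, where the earlier groups each have one, and it carries no halogen, yet in this assay the outcome is a number 1 percentage points higher from compound 3 to compound 4 (within the scatter). The comparisons with the other two groups read the same way: no change at the digits printed from compound 2 to compound 4 (within the scatter), and a number 1 percentage points higher from compound 1 to compound 4 (within the scatter). So this position has now taken a larger, two-ring aromatic group as well as the single-ring ones, and all four compounds remain at the bottom of the scale with no separation beyond the scatter, although nothing measured here explains this reading.

As far as these compounds go, what remains open is whether a group of another kind on this nitrogen, such as cyclohexyl, a longer carbon chain or a chain ending in a carboxylic acid, would lift the reading above the scatter. Also open, from the compounds shown here alone, is whether a change elsewhere in the shared core, such as an amide in place of the free amine or another halogen in place of the chlorine, would do so when the aromatic group stays the same.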